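This account rests on a few compounds, and the source may have more. Where it says the series, first, only, none or still open, it means among the compounds named here.

Measured in a functional assay on HCT-116 cells (Homo sapiens) for antiproliferative activity, read by MTT assay, with a stated time of 72 h; on this read-out lower numbers stand for stronger inhibition and higher numbers for weaker inhibition:

compound 1 `Nc1ccc(SCC(=O)Nc2ccc3nc(NC(=O)c4ccc(C(F)(F)F)cc4)sc3c2)cc1`: 100 nM
compound 2 `COc1cc(CNC(C)(C)CO)ccc1OCC(=O)Nc1ccc(C)cc1`: > 100000 nM (a limit of the assay)
compound 3 `Cc1cc(C)cc(C(=O)Nc2nc3ccc(NC(=O)CSc4ccc(Cl)cc4)cc3s2)c1`: 65100 nM

Of the two actual numbers, compound 1 at 100 nM holds the lower, and the gap to compound 3 at 65100 nM lies well beyond the scatter.

Going by the values given here, the next compound to be tested in this assay is compound 4 `O=C(CSC1CCCCC1)Nc1ccc2nc(NC(=O)c3ccc(C(F)(F)F)cc3)sc2c1`, which keeps the core of compound 1 and carries cyclohexyl in place of 4-aminophenyl on a sulfur as its only change. Among the compounds with values here, no two measured compounds differ in just one place, so this step has no direct precedent. The nearest guide is compound 3, which shares the core but differs from compound 1 in more than one place. Compound 3 at 65100 nM stands far from compound 1 at 100 nM in this small set, so a large move cannot be ruled out, though a single change may well cost less. A rise in the number beyond the scatter is therefore expected, with an estimated 10-fold higher number from compound 1 to compound 4 (1.00 log units; beyond the scatter) as the likely size of the step. For compound 4 the expected value is 1000 nM as a best estimate, with an expected range from 150 nM to 15000 nM around it.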

Compound 4, half-maximal inhibitory concentration: 21000 nM
The estimate for compound 4 lay 21-fold (1.32 log units) below the measured number; the measured number lies above the stated range.
By their numbers in this assay, from the lowest: compound 1; then compound 4; then compound 3. At a limit, above all of these: compound 2.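

In this assay, the exchange of 4-aminophenyl for cyclohexyl, on a sulfur whose other neighbour is a saturated chain carbon, gives the series its first comparison in which only one place differs, and it comes with a 210-fold higher number from compound 1 to compound 4 (2.32 log units; beyond the scatter). The rest of compound 1 stays in place, so this position is shown to matter greatly to the read-out, and a six-membered carbon ring at this sulfur does not by itself preserve the low number of compound 1. The change removes both the aromatic character of the ring and the amine with its hydrogen-bond donor and acceptor count, and nothing among the measurements shown accounts for the size of the step.

As far as these compounds go, whether the step follows from the loss of the aromatic ring or from the loss of the amine remains open, since both changed together; a plain phenyl or a 4-aminocyclohexyl on the same sulfur would separate the two. From the compounds shown here alone, how a 4-hydroxyphenyl or an open carbon chain at this position would compare with compound 1 also remains unknown.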